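The compounds below may be only part of what the source reports. "The series", "measured", "known", "first", "only" and "open" are said of these compounds alone.

Measured so far:
compound 1, `O=S(=O)(/C=C/c1ccccn1)c1ccccc1F`, 1050 nM
compound 2, `O=S(=O)(/C=C\c1ncccc1F)c1ccccc1F`, 482 nM
compound 3, `O=S(=O)(/C=C\c1ncccc1Cl)c1ccccc1F`, 1030 nM

All three values come from an assay on U2OS cells for activation of nuclear factor erythroid 2-related factor 2 (Homo sapiens), read by beta-arrestin recruitment, with a stated time of 6 h; a lower number here means that less compound is needed, a higher number that more compound is needed for the effect. Compound 2 differs from compound 1 by more than a single change; the difference between the two cores is not broken down here, and their values simply show compound 2 with the lower number, beyond the scatter. Compound 1 and compound 3 sit within the scatter of each other.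

One change has a measured step: from compound 2 to compound 3, (chloro in place of fluoro on an aromatic carbon), giving a 2.1-fold higher number from compound 2 to compound 3 (0.33 log units; beyond the scatter). The same kind of change is made from compound 1 to compound 4, `O=S(=O)(/C=C/c1ccccn1)c1ccccc1Cl`: chloro in place of fluoro on an aromatic carbon. It is not the same change, since in compound 2 the place is on a six-membered aromatic ring with 1 nitrogen, two atoms from the ring nitrogen, whereas in compound 1 it is on a six-membered aromatic ring of carbon only.

With a single precedent, the step from compound 1 to compound 4 is expected to resemble that earlier one, a 1.9-fold higher number from compound 1 to compound 4 (0.28 log units; within the scatter) beside a 2.1-fold higher number from compound 2 to compound 3 (0.33 log units; beyond the scatter), with wide uncertainty because the two places differ. Compound 4 is therefore estimated at 2000 nM in this assay, between 900 nM and 4500 nM.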

Compound 4, half-maximal effective concentration: 618 nM
For compound 4 the middle estimate is 3.2-fold (0.51 log units) above the measured one, and the stated range ends above it.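

In this assay, going by these compounds alone, chloro in place of fluoro on an aromatic carbon of the ring of carbon only gives a 1.7-fold lower number from compound 1 to compound 4 (0.23 log units; within the scatter), so on this core the swap produces no step that stands clear of the scatter. The swap therefore does not carry over as a fixed step from one core to the other: the same change on two cores in this assay, a 2.1-fold higher number (0.33 log units; beyond the scatter) from compound 2 to compound 3 and a 1.7-fold lower number (0.23 log units; within the scatter) from compound 1 to compound 4, 3.6-fold (0.56 log units) apart, beyond the scatter of two such steps What this does not show is whether the gap follows the ring carrying the swap or the rest of the core: the two steps differ in both, and a single pair on each gives no rule for a further core.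

The compounds shown leave open how a group other than the two halogens, such as methoxy, a nitrile or an amine, would read at these places on either ring. Also open, on these data alone, is how a carboxylic acid would read there, and whether chloro on both rings of one compound would follow either step.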